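Swapping 4-Methylbenzyl for 4-Methylphenyl on a Sulfur

The compounds below may be only part of what the source reports. "The series", "measured", "known", "first", "only" and "open" are said of these compounds alone.

Of the compounds shown here, two with a shared core have been measured so far. In a functional assay on DU-145 cells (Homo sapiens) for inhibition, read by trypan blue exclusion, with a stated time of 96 h (a lower number here means a stronger inhibitor of growth, a higher number a weaker inhibitor of growth), compound 1 `Cc1ccc(CS/C(=C/c2ccc(F)c(C)c2)C(=O)c2ccc(Cl)cc2)cc1` gives 25000 nM, while compound 2 `Cc1ccc(CS/C(=C/c2c[nH]c3ccc(Br)cc23)C(=O)c2ccc(Cl)cc2)cc1` gives 1000 nM, the lower of the two numbers. For the measured compounds named here, the only measured step, a 25-fold lower number from compound 1 to compound 2 (1.40 log units; beyond the scatter), is large and lies beyond the scatter. It comes with 5-bromo-1H-indol-3-yl in place of 4-fluoro-3-methylphenyl, and the group on the sulfur stays the same.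

The next compound, compound 3 `Cc1ccc(S/C(=C/c2c[nH]c3ccc(Br)cc23)C(=O)c2ccc(Cl)cc2)cc1`, keeps the 5-bromo-1H-indol-3-yl group of compound 2 and carries 4-methylphenyl in place of 4-methylbenzyl on a sulfur. The measured step therefore bears on this change only indirectly. It shows that the series can respond strongly to a change at another place, but it gives no size or direction for a change at the sulfur. With no direct evidence, no shift beyond the scatter is the working expectation, held with wide uncertainty. The expected change in this assay is a small one, a 1.5-fold higher number from compound 2 to compound 3 (0.18 log units; within the scatter). For compound 3 the estimated value is 1500 nM, with an expected range of 400 nM to 6000 nM.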

Compound 3, concentration for 50% growth inhibition: 1000 nM
Compound 3: the middle estimate sits 1.5-fold (0.18 log units) above what was measured, and the stated range covers the measured number.
By their numbers in this assay, from the lowest: compounds 2 and 3 (each within the scatter of the next); then compound 1.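

In this assay, for the compounds shown here, the change from (4-methylbenzyl)sulfanyl to (4-methylphenyl)sulfanyl gives no change at the digits printed from compound 2 to compound 3 (within the scatter) and is the first direct reading at this position, which until now had only been held constant. With the 5-bromo-1H-indol-3-yl group in place, the group on the sulfur can therefore go from 4-methylbenzyl to 4-methylphenyl with no shift beyond the scatter, in contrast to the large response at the double-bonded chain carbon, a 25-fold lower number from compound 1 to compound 2 (1.40 log units; beyond the scatter) in the same assay. Nothing measured here explains why this swap leaves the number unmoved.

This single step rests on one partner group, so the compounds shown leave open whether the same swap would be equally silent with 4-fluoro-3-methylphenyl in place of 5-bromo-1H-indol-3-yl. They also leave open how far this position would tolerate groups of a different kind on the sulfur, such as a longer chain ending in the same aromatic ring, a chain carrying an amine or a carboxylic acid, or a 4-methylphenyl ring without its methyl group.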